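A larger amine on the chain: what compound 3 may show

This account rests on a few compounds, and the source may have more. Where it says the series, first, only, none or still open, it means among the compounds named here.

Measured so far:
Compound 1, `CC(C)N(CCn1cc[n+](C)c1/C=N/O)C(C)C`, gives -1.79 in a physicochemical assay for lipophilicity; on this read-out higher numbers stand for higher lipophilicity and lower numbers for lower lipophilicity.
Compound 2, `CN(C)CCCn1cc[n+](C)c1/C=N/O`, gives < -3 in this assay, which is a limit of the assay rather than a number.

Compound 2 thus stands at the limit of < -3 in this assay, at which 1 of the 2 values shown sits, the lower of the two values shown. Compound 3, `CCN(CC)CCCn1cc[n+](C)c1/C=N/O`, differs from it by diethylamino in place of dimethylamino on a saturated chain carbon, three bonds along the chain from an aromatic nitrogen. Within the data shown here, no measured step of this kind is available for comparison. The expectation is that this change moves the read-out upward in this assay by more than the usual scatter. Compound 3 is expected to give -2.6 in this assay, within a range from -3.4 to -1.9. The expected step is a number at least 0.40 log units higher from compound 2 to compound 3 (beyond the scatter).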

Compound 3, distribution coefficient: -2.78
For compound 3 the middle estimate is 0.18 log units above the measured one; measured number inside the range.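

With diethylamino in place of dimethylamino on a saturated chain carbon, three bonds along the chain from an aromatic nitrogen, this assay now gives a readable step at this position (a number at least 0.22 log units higher from compound 2 to compound 3 (that floor lies within the scatter)). That step shows a floor only, so it does not establish a rise beyond the scatter. Its full size cannot be fixed because compound 2 carries a limit of the assay rather than a number: the limit of < -3 in this assay, at which 1 of the 3 values shown sits.

As far as these compounds go, what a ring amine such as piperidine, or a longer chain, would give at this position stays open.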